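The compounds below may be only part of what the source reports. "The series", "measured", "known", "first", "only" and "open" are said of these compounds alone.

Of the compounds shown here, two have so far been tested in a functional assay on HeLa cells (Homo sapiens) for antiproliferative activity, read by MTT assay, with a stated time of 3 days; a lower number here means a stronger inhibitor, a higher number a weaker inhibitor. Compound 1 `O=C1c2ccccc2C(=O)N1C/C=C\Cn1cc(C#Cc2ccc(Br)cc2)c(=O)[nH]c1=O` carries a 4-bromophenyl group on a triple-bonded carbon, and in this assay compound 1 gives 87000 nM. Compound 2 `CCCCC#Cc1cn(C/C=C\CN2C(=O)c3ccccc3C2=O)c(=O)[nH]c1=O` carries butyl in the same place, and in this assay compound 2 gives 33000 nM. Among the compounds with values here, compound 2 thus holds the lower number of the two, with compound 1 as its only neighbour; the step of a 2.6-fold lower number from compound 1 to compound 2 (0.42 log units; beyond the scatter) is the single measured change, and it shows a modest gain when the aromatic ring was replaced by the plain chain. Compound 3 `CCCCc1ccc(C#Cc2cn(C/C=C\CN3C(=O)c4ccccc4C3=O)c(=O)[nH]c2=O)cc1` differs from compound 2 in one place: 4-butylphenyl in place of butyl on a triple-bonded carbon. Within the data shown here, this brings an aromatic ring back onto the triple-bonded carbon, as in compound 1, but with butyl rather than bromine on that ring, a combination no measured compound covers. Among the measured compounds shown here, the one relevant step, a 2.6-fold lower number from compound 1 to compound 2 (0.42 log units; beyond the scatter), points to a higher number with an aromatic ring in that place, so the expected step of a 1.7-fold higher number from compound 2 to compound 3 (0.22 log units; within the scatter) in this assay runs toward a higher number, of uncertain size. Compound 3 is therefore expected to give about 55000 nM in this assay, with a likely range from 20000 nM to 150000 nM.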

Compound 3, half-maximal inhibitory concentration: 85000 nM
Beside the measured number, compound 3's estimate is 1.5-fold (0.19 log units) below it; measured number inside the range.
By their numbers in this assay, from the lowest: compound 2; then compounds 3 and 1 (each within the scatter of the next).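

In this assay, the step of a 2.6-fold higher number from compound 2 to compound 3 (0.41 log units; beyond the scatter) shows that the gain seen with plain butyl on the triple-bonded carbon is lost once a six-membered aromatic ring returns there, even though the butyl chain is still present in 4-butylphenyl. The step of a 1.0-fold lower number from compound 1 to compound 3 (0.01 log units; within the scatter) lies within the scatter, so exchanging bromo for butyl on an aromatic carbon of that ring makes no readable difference, and compounds 1 and 3 cannot be put in order; among these three compounds, both that carry the ring have higher numbers than compound 2, which carries the plain chain. No supporting measurement offers an explanation for this result.

The compounds shown leave open whether a shorter or longer plain chain than butyl on the triple-bonded carbon would give a lower number than compound 2 does, or whether a chain ending in an amine or a carboxylic acid would fit the same trend. They also leave open whether a ring carrying a methoxy group or an amine would stay with compounds 1 and 3 or come closer to compound 2.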